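The source may hold more compounds than are shown below. What is called first, only, known or untested is meant among the compounds shown, and "the series" means these compounds.

In a functional assay on the whole organism (strain A/J) for inhibition, with Mus musculus as the target, with stated times of 1 h and 18 h, at a dose of 100 umol/kg by the oral route (a higher number here means more inhibition at the dose given (going by the name of the read-out), a lower number less inhibition), compound 1 `COc1ccc(/C=N/N(C)C(=O)c2ccccc2OC)cc1OC` gives 99%, and compound 2 `COc1ccc(/C=N/N(C)C(=O)c2ccccc2)cc1OC` gives 53%, the lowest of the two numbers. The one step shown, a number 46 percentage points lower from compound 1 to compound 2 (beyond the scatter), is large. For the measured compounds named here, compound 3 `COc1ccc(/C=N/N(C)C(=O)c2ccc(O)cc2)cc1OC` differs from compound 2 by hydroxy in place of hydrogen on an aromatic carbon; no measured step covers this change itself. Going by the values given here, the only step at hand concerns an oxygen substituent on the same ring and points upward when one is present, so a moderate rise in this assay is expected, a number 12 percentage points higher from compound 2 to compound 3 (beyond the scatter). For compound 3 the expected value in this assay is 65%, within 35% to 90%.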

Compound 3, a percentage reported as inhibition, in the whole organism at one dose (the size of the read-out at that dose, not a potency): 6%
Beside the measured number, compound 3's estimate is 59 percentage points above it; measured number below the stated range.
By their numbers in this assay, from the lowest: compound 3; then compound 2; then compound 1.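

In this assay, hydroxy on the aromatic carbon para to a large group brings a number 47 percentage points lower from compound 2 to compound 3 (beyond the scatter), so an oxygen substituent on this ring does not go with more inhibition in every case. The change from phenyl to 4-hydroxyphenyl runs opposite to the effect of the 2-methoxyphenyl of compound 1, and 4-hydroxyphenyl in place of 2-methoxyphenyl spans a number 93 percentage points lower from compound 1 to compound 3 (beyond the scatter). Nothing at hand bears on the reason for this drop.

From the compounds shown here alone, whether the low number belongs to hydroxy itself or to its place remains open. An amine or a carboxylic acid para to the large group would test how far the effect extends beyond hydroxy.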